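The compounds below may be only part of what the source reports. "The series", "measured", "known", "first", "only" and "open" are said of these compounds alone.

In an ADME assay on the whole organism (strain FVB) for pharmacokinetics, with Mus musculus as the target, read by LC-MS, at a dose of 30 mg/kg by the oral route (a lower number here means less compound in the circulation, a higher number more compound in the circulation at the dose given), compound 1 (`c1cc([C@H]2CC[C@]3(CC2)OOC2(O3)C3CC4CC(C3)CC2C4)ccc1OCCOC1CCNCC1`) gives 9180 ng.h/mL and compound 2 (`CC(C)(O)CNCCCOc1ccc([C@H]2CC[C@]3(CC2)OOC2(O3)C3CC4CC(C3)CC2C4)cc1`) gives 11100 ng.h/mL while compound 3 (`N[C@H]1CC[C@@H](Oc2ccc([C@H]3CC[C@]4(CC3)OOC3(O4)C4CC5CC(C4)CC3C5)cc2)CC1`) gives 13400 ng.h/mL with all three within the scatter of one another. On these numbers, compound 3 cannot be separated from the other two. Compound 4 (`CC(C)(CN)Oc1ccc([C@H]2CC[C@]3(CC2)OOC2(O3)C3CC4CC(C3)CC2C4)cc1`) keeps the shared core but carries 1-(aminomethyl)-1-methylethyl in place of 4-aminocyclohexyl on an oxygen on an aromatic ring. Two measured steps change the group at this same place: a 1.5-fold higher number from compound 1 to compound 3 (0.16 log units; within the scatter) and a 1.2-fold higher number from compound 2 to compound 3 (0.08 log units; within the scatter) and both stay within the scatter. Neither step involves the entering group, so they offer only an indirect guide. No step beyond the scatter is therefore expected in this assay for this change. The estimated size is a 1.3-fold lower number from compound 3 to compound 4 (0.13 log units; within the scatter) and this remains an expectation until compound 4 is measured. For compound 4 the estimated value is 10000 ng.h/mL with an expected range from 4500 ng.h/mL to 22000 ng.h/mL in this measurement.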

Compound 4, area under the concentration-time curve: 4840 ng.h/mL
Compound 4: the middle estimate sits 2.1-fold (0.32 log units) above what was measured, within the range that was stated.
By their numbers in this assay, from the lowest: compounds 4, 1, 2 and 3 (each within the scatter of the next, the first and the last beyond it).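

In this assay, the place on an oxygen on an aromatic ring now shows a change that goes beyond the scatter: 1-(aminomethyl)-1-methylethyl gives a 2.8-fold lower number from compound 3 to compound 4 (0.44 log units; beyond the scatter) and a 2.3-fold lower number from compound 2 to compound 4 (0.36 log units; beyond the scatter), whereas the three earlier groups could not be separated from one another. Compound 1 goes against a clean separation, as the same group gives a 1.9-fold lower number from compound 1 to compound 4 (0.28 log units; within the scatter), which stays within the scatter, so compound 4 stands apart from only two of the three earlier compounds. Nothing available explains this lower number.

On these data alone, whether it goes with the loss of the six-membered ring of 4-aminocyclohexyl or with the 1-(aminomethyl)-1-methylethyl group itself remains open. A 3-aminocyclobutyl group or a straight 2-aminoethyl chain on the same oxygen would bear on that question.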